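The source may hold more compounds than are shown below. What is called first, only, known or untested is meant among the compounds shown, and "the series" means these compounds.

Compound 1 `Cc1cc(NC(=O)Nc2ccc(C(C)(C)C)cc2)c2ccccc2n1` — > 25000 nM
Compound 2 `Cc1cc(NC(=O)Nc2cccc3nsnc23)c2ccccc2n1` — > 25000 nM
Compound 3 `Cc1cc(NC(=O)Nc2cccc(C(F)(F)F)c2)c2ccccc2n1` — 10000 nM

The three measured compounds share one core and differ only in the aromatic ring attached to the urea. In an ADME assay on Raji cells (Homo sapiens) for cytotoxicity, with a stated time of 72 h (on this read-out lower numbers stand for an effect already at smaller amounts and higher numbers for an effect only at larger amounts of compound), compound 1 is recorded only as a limit, > 25000 nM. Compound 2 also sits at a limit in this assay, > 25000 nM. Compound 3 gives a number in this assay, 10000 nM. Compound 4 `Cc1cc(NC(=O)Nc2ccc(C(=O)O)cc2)c2ccccc2n1` is not yet measured; it differs from compound 1 by carboxy in place of tert-butyl on an aromatic carbon. Among the measured compounds shown here, no pair of measured compounds differs in one place, so no measured step size exists. Because compound 1 sits at the limit (the limit of > 25000 nM in this assay, at which 2 of the 3 values shown sit), the step that the limit leaves unreadable from compound 1 to compound 4 is expected to be none beyond the scatter. Compound 4 is therefore expected to give about 30000 nM, with a range from 12000 nM to 80000 nM.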

Compound 4, half-maximal effective concentration: > 25000 nM
Compound 4 was reported as a limit (the forecaster's own chance of this, stated with the estimate: 80%); the middle value does not contradict the limit.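

Among the compounds shown here, compound 1 and compound 4 are both recorded only as limits, so no step between them can be read: the limit of > 25000 nM in this assay, at which 3 of the 4 values shown sit.

The compounds shown leave open whether carboxy in place of tert-butyl changes the result in this assay at all.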